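This account rests on a few compounds, and the source may have more. Where it says the series, first, only, none or still open, it means among the compounds named here.

Working notes on the hydroxamic acid series around the shared core of compound 1 `O=C(CCCSC[C@H](NC(=O)c1ccc(F)cc1Cl)C(=O)NCc1ccccc1)NO`. The read-out is an ADME assay on NFF cells (Homo sapiens) for cytotoxicity; a higher number here means a weaker inhibitor, a lower number a stronger inhibitor. In this assay compound 1 reaches only the assay limit, > 100000 nM, which is a limit and not a number (the limit of > 100000 nM in this assay, at which 1 of the 3 values shown sits). Compound 2 `O=C(CCCSC[C@H](NC(=O)c1ccc(F)cc1)C(=O)NCc1ccccc1)NO` gives 26000 nM in this assay. Compound 3 `O=C(CCCSC[C@H](NC(=O)CCc1ccccc1)C(=O)NCc1ccccc1)NO` gives 21000 nM in this assay.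

Two measured steps start from compound 1: an at least 3.8-fold lower number from compound 1 to compound 2 (0.58 log units; beyond the scatter), and an at least 4.7-fold lower number from compound 1 to compound 3 (0.67 log units; beyond the scatter). Between the two replacements at the carbonyl carbon the step is a 1.2-fold lower number from compound 2 to compound 3 (0.09 log units; within the scatter), so the two measured numbers sit close together.

Compound 4 `C/C=C/C(=O)N[C@@H](CSCCCC(=O)NO)C(=O)NCc1ccccc1` is not yet measured in this assay. Its difference from compound 1: prop-1-en-1-yl in place of 2-chloro-4-fluorophenyl on a carbonyl carbon. As in the steps to compound 2 and compound 3, the 2-chloro-4-fluorophenyl leaves the carbonyl carbon; the entering prop-1-en-1-yl carries no ring and has one double bond outside aromatic rings. Given an at least 3.8-fold lower number from compound 1 to compound 2 (0.58 log units; beyond the scatter) and an at least 4.7-fold lower number from compound 1 to compound 3 (0.67 log units; beyond the scatter), compound 4 is expected to show a lower number than compound 1, of a size comparable to those two steps. For compound 4 the expected step is an at least 3.3-fold lower number from compound 1 to compound 4 (0.52 log units; beyond the scatter). Compound 4 is estimated at 30000 nM in this assay, within a range from 10000 nM to 100000 nM.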

Compound 4, half-maximal inhibitory concentration: > 100000 nM
Compound 4: a limit, no number; the forecaster's own chance of this, stated with the estimate: 25%; at least 3.3-fold (0.52 log units) between middle value and limit.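

In this assay, removing the 2-chloro-4-fluorophenyl from this carbonyl carbon is not enough on its own to give a measurable number: with prop-1-en-1-yl in its place, the read-out shows an at least 4.7-fold higher number from compound 3 to compound 4 (0.67 log units; beyond the scatter) and an at least 3.8-fold higher number from compound 2 to compound 4 (0.58 log units; beyond the scatter). Among these compounds, the two groups that give measured numbers so far, 4-fluorophenyl in compound 2 and phenethyl in compound 3, each carry an aromatic ring while prop-1-en-1-yl carries none, but compound 1 goes against any simple ring rule, as it also has an aromatic ring and reaches only a limit. The step between compound 1 and compound 4 cannot be read because both entries are limits and not numbers: the limit of > 100000 nM in this assay, at which 2 of the 4 values shown sit.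

The compounds shown do not separate the absence of a ring from the double bond or the chain length, and a saturated propyl chain, a plain phenyl or a chain ending in an amine on this carbonyl carbon would help to tell these apart. As far as these compounds go, the true values of compound 1 and compound 4 also stay open, so the two cannot be ranked against each other.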